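Methyl to isopropyl ester on two cores, nitro-aryl series

The compounds below may be only part of what the source reports. "The series", "measured", "known", "first", "only" and "open" are said of these compounds alone.

Compound 1 `COC(=O)C1=C(C)NC(=S)NC1c1cccc([N+](=O)[O-])c1` and compound 2 `CC1=C(C(=O)OC(C)C)C(c2cccc([N+](=O)[O-])c2)NC(=S)N1` share one core; compound 3 `COC(=O)C1=C(C)OC(N)=C(C(=O)OC(C)C)C1c1cccc([N+](=O)[O-])c1` and compound 4 `CC1=C(C(=O)OC(C)C)C(c2cccc([N+](=O)[O-])c2)C(C(=O)OC(C)C)=C(N)O1` share another, and the difference between the two cores is not broken down here. In an assay on HEK293 cells for antagonist activity at Voltage-dependent L-type calcium channel subunit alpha-1C (Oryctolagus cuniculus), read by FLIPR (a higher number here means a weaker inhibitor, a lower number a stronger inhibitor), compound 1 gives 55000 nM and compound 2 gives 10700 nM; the change isopropyl in place of methyl on an oxygen next to a carbonyl group made a step of a 5.1-fold lower number from compound 1 to compound 2 (0.71 log units; beyond the scatter). Compound 3 gives 410 nM in this assay, the lowest of the three measured numbers. The same change, (isopropyl in place of methyl on an oxygen next to a carbonyl group), is applied on the second core to give compound 4. The earlier step rests on one pair only and on a different core, so a smaller move is expected here: compound 4 is estimated at 200 nM in this assay, a step of a 2.1-fold lower number from compound 3 to compound 4 (0.31 log units; beyond the scatter), with a range from 60 nM to 600 nM.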

Compound 4, half-maximal inhibitory concentration: 860 nM
Compound 4: the middle estimate sits 4.3-fold (0.63 log units) below what was measured; measured number above the stated range.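

On the core of compound 3 in this assay, isopropyl in place of methyl on an oxygen next to a carbonyl group gives a 2.1-fold higher number from compound 3 to compound 4 (0.32 log units; beyond the scatter), so the step seen on the first core does not carry over to this one. Set side by side, the two steps run in opposite directions: the same change on two cores in this assay, a 5.1-fold lower number (0.71 log units; beyond the scatter) from compound 1 to compound 2 and a 2.1-fold higher number (0.32 log units; beyond the scatter) from compound 3 to compound 4, 11-fold (1.03 log units) apart, beyond the scatter of two such steps. This shows that the step depends on the core within these four compounds, but with one pair per core and the difference between the cores not broken down, it does not show which feature of the core is responsible.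

Still open, from the compounds shown here alone, is whether an ethyl or tert-butyl ester in the same place would follow the step of either core. Also open, going by these compounds, is how a carboxylic acid there would read on the two cores.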